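Swapping the Amine Chain for an Amide Chain

A few compounds are considered here, and "the series" means these few. Any claim that something is new, unique, unknown or untested is made for them only; others in the source may bear on it.

Measured compounds:
compound 1, `CC(C)C[C@@H]1NC(=O)[C@H](CS)NC1=O`: in a functional assay, tested at 2.5 mM (on this read-out higher numbers stand for more inhibition at the one concentration tested (going by the name of the read-out) and lower numbers for less inhibition), compound 1 gives 83.3%.
compound 2, `CC(C)C[C@@H]1NC(=O)[C@H](C)NC1=O`: compound 2 gives 0%.
compound 3, `CC(C)C[C@@H]1NC(=O)[C@H](CCCCN)NC1=O`: compound 3 gives 0%.

Compound 3 stands level with compound 2 at the digits shown, and the two share the lowest number of the three; only compound 1 sits apart from it, with a higher value. The three measured steps tell one story: a number 83.3 percentage points lower from compound 1 to compound 2 (beyond the scatter) and a number 83.3 percentage points lower from compound 1 to compound 3 (beyond the scatter) are both large, while no change at the digits printed from compound 2 to compound 3 (within the scatter) is flat. Only the sulfanyl-bearing compound 1 inhibits; the hydrogen- and 3-aminopropyl-bearing compounds do not.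

Compound 4, `CC(C)C[C@@H]1NC(=O)[C@H](CCC(N)=O)NC1=O`, differs from compound 3 by carbamoyl in place of 2-aminoethyl on a saturated chain carbon, two bonds along the chain from a saturated ring carbon. For the measured compounds named here, no measured step covers an amide-bearing chain, so the measured steps bear on it only indirectly: they show that two quite different non-sulfanyl side chains both gave no inhibition. On that basis the step of no change at the digits printed from compound 3 to compound 4 (within the scatter) is expected to stay within the scatter, with no inhibition gained. For compound 4 the estimate is 0%, ranging from 0% to 15%.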

Compound 4, a percentage reported as inhibition, at one concentration (the size of the read-out at that concentration, not a potency): 0%
Compound 4: middle estimate and measured number agree at the digits printed; measured number inside the range.
By their numbers in this assay, from the lowest: compounds 2, 3 and 4 (each within the scatter of the next); then compound 1.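

Putting carbamoyl in place of 2-aminoethyl, on a saturated chain carbon two bonds along the chain from a saturated ring carbon, gives no change at the digits printed from compound 3 to compound 4 (within the scatter) in this assay and so adds no inhibition. Carbamoylmethyl in place of hydrogen gives no change at the digits printed from compound 2 to compound 4 (within the scatter) and thus also adds none, whereas carbamoylmethyl in place of sulfanyl gives a number 83.3 percentage points lower from compound 1 to compound 4 (beyond the scatter) and loses the inhibition seen with compound 1. A chain ending in an amide therefore joins the hydrogen and amine-ending chains as a replacement that does not stand in for sulfanyl.

Still open, from the compounds shown here alone, is whether a hydroxyl or a methylsulfanyl group at this position would keep any inhibition. Also open, going by these compounds, is whether a sulfanyl group on a longer chain would do so. No supporting information explains why only the sulfanyl compound inhibits.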